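Oxazoline for thiazoline on the isoxazoline sulfone series

The source may hold more compounds than are shown below. What is called first, only, known or untested is meant among the compounds shown, and "the series" means these compounds.

Measured so far:
- compound 1 `O=S(=O)(CC1=NCCS1)C1C(c2ccccc2)=NOC1c1ccccc1`: "not active" (no number reported)
- compound 2 `COc1ccc(C2=NOC(c3ccc(C)cc3)C2S(=O)(=O)CC2=NCCO2)cc1`: 61.9%
- compound 3 `COc1ccc(C2=NOC(c3ccc(C)cc3)C2S(=O)(=O)CC2=NCCS2)cc1`: 48.6%

In a functional assay, read by Griess assay, with a stated time of 150 min, tested at 50 ug/mL (a higher number here means a stronger effect of the compound at the concentration tested, a lower number a weaker effect), compound 2 gives 61.9% and compound 3 gives 48.6%. The step between them is a number 13.3 percentage points higher from compound 3 to compound 2 (beyond the scatter), the change being (a group of 5 heavy atoms (3 carbon, 1 nitrogen, 1 oxygen; one five-membered non-aromatic ring with 2 hetero atoms) in place of a group of 5 heavy atoms (3 carbon, 1 nitrogen, 1 sulfur; one five-membered non-aromatic ring with 2 hetero atoms), on a saturated chain carbon bound to a sulfonyl sulfur). Compound 1 is recorded in this assay as "not active" (no number reported), with no number given. How the core of compound 1 differs from the core of compound 3 is not broken down here.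

Compound 4 `O=S(=O)(CC1=NCCO1)C1C(c2ccccc2)=NOC1c1ccccc1` is not yet measured. It carries the same kind of change relative to compound 1, namely (a group of 5 heavy atoms (3 carbon, 1 nitrogen, 1 oxygen; one five-membered non-aromatic ring with 2 hetero atoms) in place of a group of 5 heavy atoms (3 carbon, 1 nitrogen, 1 sulfur; one five-membered non-aromatic ring with 2 hetero atoms), on a saturated chain carbon bound to a sulfonyl sulfur), at the same place as in the pair already measured. Within the data shown here, the only guidance is the single step from compound 3 to compound 2, which was modest; compound 1 gives no number to add it to. If the change behaves alike on the core of compound 1, compound 4 is expected to move up only modestly from an inactive starting point, and may itself be reported without a number. Compound 4 is estimated at 18% in this assay, within 2% to 38%.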

Compound 4, a percentage reported as activity, at one concentration (the size of the read-out at that concentration, not a potency): 53.9%
Estimate against measurement, compound 4: 35.9 percentage points below; measured number above the stated range.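

In this assay compound 1 is recorded as "not active" (no number reported) and compound 4 gives 53.9%, so no numerical step can be read between compound 1 and compound 4. Nothing shown here bears on the reason for this result. The compounds shown leave open whether this ring change has a similar effect on both cores.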